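A Pyridylpiperazine in Place of a Dimethylmorpholine

The source may hold more compounds than are shown below. What is called first, only, known or untested is meant among the compounds shown, and "the series" means these compounds.

Compound 2 `COc1ccc2[nH]c(C(=O)N3CC(=O)N(Cc4ccccc4)[C@@H](CN4[C@H](C)COC[C@@H]4C)C3)cc2c1` was examined in a physicochemical assay for solubility, read by spectrophotometry, in phosphate buffer, with a stated time of 2 h, at pH 7.4; on this read-out higher numbers stand for higher solubility and lower numbers for lower solubility. In this assay compound 2 gives > 100000 nM, which is a limit of the assay and not a number. Compound 1 `COc1ccc2[nH]c(C(=O)N3CC(=O)N(Cc4ccccc4)[C@@H](Cc4ccccn4)C3)cc2c1` differs from compound 2 in one place, carrying pyridin-2-yl where compound 2 carries 3,5-dimethylmorpholin-4-yl on a saturated chain carbon bound to a saturated ring carbon. In this assay compound 1 gives > 100000 nM, again a limit rather than a number. The step that the two limits leave unreadable from compound 1 to compound 2 therefore cannot be read in size, and both values sit at the limit of > 100000 nM in this assay, at which 2 of the 2 values shown sit. Compound 3 `COc1ccc2[nH]c(C(=O)N3CC(=O)N(Cc4ccccc4)[C@@H](CN4CCN(c5ccccn5)CC4)C3)cc2c1` has not yet been measured. It is made from compound 2 by 4-(pyridin-2-yl)piperazin-1-yl in place of 3,5-dimethylmorpholin-4-yl on a saturated chain carbon bound to a saturated ring carbon. Within the data shown here, no measured step bears on this change: the only step in the set is unreadable, so there is no ground for expecting a step beyond the scatter in either direction, and the estimate for compound 3 is accordingly uncertain. Compound 3 is expected to give 100000 nM, with a range from 30000 nM to 300000 nM, which means an estimated step of a number no higher from compound 2 to compound 3 (the limit leaves the size open).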

Compound 3, solubility: 30200 nM
For compound 3 the middle estimate is 3.3-fold (0.52 log units) above the measured one, within the range that was stated.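

In this assay, the position on a saturated chain carbon bound to a saturated ring carbon now shows a step that can be read, at least as a lower bound: 4-(pyridin-2-yl)piperazin-1-yl in place of 3,5-dimethylmorpholin-4-yl gives an at least 3.3-fold lower number from compound 2 to compound 3 (0.51 log units; beyond the scatter). The same group in place of pyridin-2-yl gives an at least 3.3-fold lower number from compound 1 to compound 3 (0.51 log units; beyond the scatter), so the entering group lowers the number against both earlier groups, whereas the step between those two could not be read. Both sizes are lower bounds only, as the values of compound 1 and compound 2 are limits of the assay and not numbers: the limit of > 100000 nM in this assay, at which 2 of the 3 values shown sit.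

The compounds shown leave open which part of the larger group goes with the lower number, the piperazine ring or the pyridin-2-yl attached to it. A plain piperazin-1-yl, or a piperazine bearing phenyl or methyl in place of the pyridin-2-yl, would separate these two parts at the same place on the shared core.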